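A few compounds are considered here, and "the series" means these few. Any claim that something is new, unique, unknown or untested is made for them only; others in the source may bear on it.

Measured so far in a functional assay on the whole organism with Canis familiaris (Canis lupus familiaris) as the target; a lower number here means that less compound is needed, a higher number that more compound is needed for the effect:
- Compound 1 `COc1ccc(-c2nc3cc[nH]cc-3n2)c(OC)c1`: 0.3 mg/kg
- Compound 2 `CCCOc1cc(OC)ccc1-c1nc2cc[nH]cc-2n1`: 1.3 mg/kg
- Compound 3 `COc1ccc(-c2nc3cc[nH]cc-3n2)c(OCCSC)c1`: 1.1 mg/kg

The low end of these numbers belongs to one compound alone. The data show a 4.3-fold higher number from compound 1 to compound 2 (0.64 log units; beyond the scatter) and also a 3.7-fold higher number from compound 1 to compound 3 (0.56 log units; beyond the scatter). At the upper end they show a 1.2-fold lower number from compound 2 to compound 3 (0.07 log units; within the scatter), so no order can be drawn there, and compound 3 shares that end of this small set.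

Compound 4 `COc1ccc(-c2nc3cc[nH]cc-3n2)c(OCC[S+](C)[O-])c1` keeps everything in compound 3 except one group, and the change is a group of 3 heavy atoms (1 carbon, 1 oxygen, 1 sulfur; no ring) in place of a group of 2 heavy atoms (1 carbon, 1 sulfur; no ring), on a saturated chain carbon, two bonds along the chain from an oxygen on an aromatic ring. It lies on a saturated chain carbon, two bonds along the chain from an oxygen on an aromatic ring.

The closest evidence is the exchange at this same place, where methylsulfanyl stands in place of methyl, and that swap gave a 1.2-fold lower number from compound 2 to compound 3 (0.07 log units; within the scatter). The two steps that built the chain out from compound 1 were modest. For the measured compounds named here, no measured compound carries the entering group, so this expectation is loose, and no step beyond the scatter is expected in this assay. The expected step is a 1.2-fold lower number from compound 3 to compound 4 (0.09 log units; within the scatter). For compound 4 the estimated value is 0.9 mg/kg, with an expected range of 0.3 mg/kg to 2.7 mg/kg.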

Compound 4, dose for half-maximal effect: 5.2 mg/kg
Compound 4: the middle estimate sits 5.8-fold (0.76 log units) below what was measured, and the stated range ends below it.
By their numbers in this assay, from the lowest: compound 1; then compounds 3 and 2 (each within the scatter of the next); then compound 4.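

In this assay, for the compounds shown here, this place on the chain had so far barely distinguished its groups: putting methylsulfanyl in place of methyl gave a 1.2-fold lower number from compound 2 to compound 3 (0.07 log units; within the scatter). The new group, which has one oxygen more than methylsulfanyl, does register here, with a 4.7-fold higher number from compound 3 to compound 4 (0.67 log units; beyond the scatter) and, against the propyl-type chain that ends in methyl, a 4.0-fold higher number from compound 2 to compound 4 (0.60 log units; beyond the scatter), so what stands at the chain end can matter and not only the presence of a chain. Going by these compounds alone, measured against the plain methoxy starting point, the full change gives a 17-fold higher number from compound 1 to compound 4 (1.24 log units; beyond the scatter), the only step in this small set that counts as large, and nothing available here explains why this group costs more dose.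

The compounds shown leave open whether the effect is specific to this oxygen-bearing sulfur group, since a sulfur carrying two oxygens, an amine or a carboxylic acid at the same chain end would each test that in a different way. They also leave open whether a shorter or longer chain carrying the same group would need a lower or higher dose in this assay.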